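The compounds below may be only part of what the source reports. "The series", "measured", "known", "first", "only" and "open" are said of these compounds alone.

In a functional assay on A549 cells (Homo sapiens) for antiproliferative activity, read by MTT assay, with a stated time of 48 h (a lower number here means a stronger inhibitor, a higher number a weaker inhibitor), compound 1 `COc1ccc(-c2cc3c(cn2)n(C)c(=O)n3-c2cc(OC)c(OC)c(OC)c2)cc1O` gives 3520 nM and compound 2 `COc1ccc(-c2cc3c(cn2)n(C(C)C)c(=O)n3-c2cc(OC)c(OC)c(OC)c2)cc1O` gives 7210 nM, so compound 2 holds the higher number of the two and is the weaker inhibitor. Compound 3 `COc1ccc(-c2cc3c(cn2)n(CC(N)=O)c(=O)n3-c2cc(OC)c(OC)c(OC)c2)cc1O` differs from compound 2 on an aromatic nitrogen: carbamoylmethyl in place of isopropyl on an aromatic nitrogen. Within the data shown here, the only measured change at that nitrogen is modest: a 2.0-fold higher number from compound 1 to compound 2 (0.31 log units; beyond the scatter). Among the measured compounds shown here, no measured compound carries a carbamoylmethyl group, so that step offers only a rough guide to size. The expected step is a 1.4-fold lower number from compound 2 to compound 3 (0.16 log units; within the scatter), which stays within the usual scatter. For compound 3 the estimated value is 5000 nM, with an expected range from 1800 nM to 14000 nM.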

Compound 3, half-maximal inhibitory concentration: 10900 nM
Estimate against measurement, compound 3: 2.2-fold (0.34 log units) below; the measured number falls inside the stated range.
By their numbers in this assay, from the lowest: compound 1; then compounds 2 and 3 (each within the scatter of the next).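

Carbamoylmethyl in place of isopropyl on this nitrogen adds a hydrogen-bond donor and acceptor, yet this assay shows only a 1.5-fold higher number from compound 2 to compound 3 (0.18 log units; within the scatter), so the two groups cannot be told apart here. Carbamoyl in place of hydrogen on the methyl group gives a 3.1-fold higher number from compound 1 to compound 3 (0.49 log units; beyond the scatter), which leaves methyl with the lowest number of the three groups shown. Nothing measured here explains these differences.

On these data alone, whether an ethyl group, a longer chain ending in an amine, or a carboxylic acid at this nitrogen would come closer to methyl remains open.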